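The source may hold more compounds than are shown below. What is called first, only, known or untested is meant among the compounds shown, and "the series" means these compounds.

Of the compounds shown here, three sharing one core have been measured in a functional assay on MKN-74 cells (Homo sapiens) for antiproliferative activity, with a stated time of 24 h; on this read-out lower numbers stand for stronger inhibition and higher numbers for weaker inhibition. Compound 1 `NC(=O)c1c(NC(=O)c2ccccc2Cl)sc2c1CCN(Cc1ccccc1Cl)C2` gives 4430 nM. Compound 2 `NC(=O)c1c(NC(=O)c2ccccc2Cl)sc2c1CCN(Cc1c(Cl)cccc1Cl)C2`, which carries a chloro in place of hydrogen on an aromatic carbon, gives 4740 nM, and the step of a 1.1-fold higher number from compound 1 to compound 2 (0.03 log units; within the scatter) shows that the two lie together. Compound 3 `NC(=O)c1c(NC(=O)c2ccccc2Cl)sc2c1CCN(C(=O)Nc1ccccc1Cl)C2`, in which a (2-chlorophenyl)carbamoyl replaces the 2-chlorobenzyl on the amine nitrogen in the ring, gives 16300 nM. Compound 3 thus stands with the highest number of the three, the weakest inhibition seen, separated from compound 2 by a 3.4-fold higher number from compound 2 to compound 3 (0.54 log units; beyond the scatter) and from compound 1 by a 3.7-fold higher number from compound 1 to compound 3 (0.57 log units; beyond the scatter).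

Compound 4 `CSc1ccccc1NC(=S)N1CCc2c(sc(NC(=O)c3ccccc3Cl)c2C(N)=O)C1` has not yet been measured. It differs from compound 3 in one place: a group of 11 heavy atoms (8 carbon, 1 nitrogen, 2 sulfur; one six-membered aromatic ring of carbon only) in place of a group of 10 heavy atoms (7 carbon, 1 nitrogen, 1 oxygen, 1 chlorine; one six-membered aromatic ring of carbon only), on an amine nitrogen in a ring. Within the data shown here, the group that enters keeps the same kind of attachment to the ring nitrogen as the one that leaves, so the two steps that bear on it, a 3.7-fold higher number from compound 1 to compound 3 (0.57 log units; beyond the scatter) and a 3.4-fold higher number from compound 2 to compound 3 (0.54 log units; beyond the scatter), both describe the move away from a benzyl group rather than the present swap itself; no measured step tests sulfur in place of oxygen or a methylthio in place of chloro. Compound 4 is therefore expected to sit near compound 3, with a step of a 1.4-fold lower number from compound 3 to compound 4 (0.13 log units; within the scatter) that may well be within the scatter. The estimate for compound 4 in this assay is 12000 nM, with a range from 5000 nM to 30000 nM.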

Compound 4, half-maximal inhibitory concentration: 13800 nM
Beside the measured number, compound 4's estimate is 1.2-fold (0.06 log units) below it; low and high end bracket the measured number.
By their numbers in this assay, from the lowest: compounds 1 and 2 (each within the scatter of the next); then compounds 4 and 3 (each within the scatter of the next).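

In this assay, the step of a 1.2-fold lower number from compound 3 to compound 4 (0.07 log units; within the scatter) shows that exchanging the (2-chlorophenyl)carbamoyl on the amine nitrogen in the ring for a group with sulfur in place of oxygen and methylthio in place of chloro leaves the read-out within the usual scatter, so this position tolerates that double change with no visible shift. The new group also stays apart from the two benzyl groups, with a 2.9-fold higher number from compound 2 to compound 4 (0.46 log units; beyond the scatter) and a 3.1-fold higher number from compound 1 to compound 4 (0.49 log units; beyond the scatter), which extends to a second compound the earlier finding that compound 3 gives a higher number than the benzyl compounds; among these four compounds, none goes against this split. Nothing available here explains why the two kinds of group differ.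

The two exchanges in compound 4 were made together, so the result cannot say what sulfur in place of oxygen or methylthio in place of chloro does alone, since opposing contributions could cancel. On these data alone, how the number would respond to a plain methyl or a longer alkyl chain on the ring nitrogen, or to an amine or carboxylic acid on the aromatic ring of this group, also remains open.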